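The compounds below may be only part of what the source reports. "The series", "measured", "known", "first", "only" and "open" are said of these compounds alone.

Measured so far in a functional assay on IMR-32 cells (Homo sapiens) for antiproliferative activity, read by sulforhodamine B assay, with a stated time of 48 h; a higher number here means a weaker inhibitor of growth, a lower number a stronger inhibitor of growth:
- compound 1 `Cc1ccc(-c2cn(CCCN3C(=O)COc4ccccc43)nn2)cc1`: 4400 nM
- compound 2 `O=C1COc2ccccc2N1CCCn1cc(-c2ccccn2)nn1`: 2000 nM
- compound 3 `O=C1COc2ccccc2N1CCCn1cc(-c2cccnc2)nn1`: 860 nM

Compound 3 has the lowest number of the three in this assay, at 860 nM. The next compound is compound 4 `O=C1COc2ccccc2N1CCCn1cc(CO)nn1`, with this change from compound 3: hydroxymethyl in place of pyridin-3-yl on an aromatic carbon. Hydroxymethyl stands in place of pyridin-3-yl on an aromatic carbon.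

Three measured steps fall at this same place: a 2.2-fold lower number from compound 1 to compound 2 (0.34 log units; beyond the scatter), a 5.1-fold lower number from compound 1 to compound 3 (0.71 log units; beyond the scatter) and a 2.3-fold lower number from compound 2 to compound 3 (0.37 log units; beyond the scatter). All are modest, but each swaps one six-membered aromatic ring for another. Among the compounds with values here, no measured compound has a group without a ring here, so the change to compound 4 goes beyond these steps and the estimate is loose. Since compound 3 is already the lowest, a higher number is expected, by a step somewhat larger than the measured ones.

For compound 4, the expected value is 4000 nM, with an estimated range of 1200 nM to 14000 nM.

The estimated change is a 4.7-fold higher number from compound 3 to compound 4 (0.67 log units; beyond the scatter).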

Compound 4, concentration for 50% growth inhibition: 5500 nM
Estimate against measurement, compound 4: 1.4-fold (0.14 log units) below, within the range that was stated.
By their numbers in this assay, from the lowest: compound 3; then compound 2; then compounds 1 and 4 (each within the scatter of the next).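

In this assay, within the data shown here, hydroxymethyl, the first group without a ring at this aromatic carbon, gives a 6.4-fold higher number from compound 3 to compound 4 (0.81 log units; beyond the scatter) and a 2.8-fold higher number from compound 2 to compound 4 (0.44 log units; beyond the scatter) in the series, so the lower numbers of the two pyridinyl compounds do not carry over to it. Against 4-methylphenyl the same kind of change gives a 1.3-fold higher number from compound 1 to compound 4 (0.10 log units; within the scatter) and stays within the scatter, so a six-membered aromatic ring here does not by itself give a lower number than a small group without a ring; among these four compounds, only pyridin-2-yl and pyridin-3-yl stand apart. Nothing available bears on why these steps arise.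

Still open, on these data alone, is where plain phenyl would fall relative to 4-methylphenyl and the pyridinyl compounds. Also open, as far as these compounds go, is how an aminomethyl group, a carboxylic acid or a longer hydroxyalkyl chain would compare with hydroxymethyl at this carbon.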